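Pentyl on selenium across two cores

The compounds below may be only part of what the source reports. "The series", "measured", "known", "first", "only" and "open" are said of these compounds alone.

Measured so far:
Compound 1 `CCCCC[Se]c1nc(NCc2ccccc2)c2ccccc2n1` gives 37700 nM in a functional assay on HTB-54 cells (Homo sapiens) for cytotoxicity, read by MTT assay, with a stated time of 72 h; a lower number here means a stronger inhibitor of growth, a higher number a weaker inhibitor of growth.
Compound 2 `[SeH]c1nc(NCc2ccccc2)c2ccccc2n1` gives 31200 nM in this assay.
Compound 3 `Nc1nc([SeH])nc2ncccc12` gives 44300 nM in this assay.

Compound 1 and compound 2 share one core and differ by a single change, (pentyl in place of hydrogen on a selenium). That change gave a 1.2-fold higher number from compound 2 to compound 1 (0.08 log units; within the scatter). Compound 3 has a different core; the difference between the two cores is not broken down here. Its value sits close to those of compound 1 and compound 2, and the gaps are within the scatter.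

Compound 4 `CCCCC[Se]c1nc(N)c2cccnc2n1` is not yet measured. It differs from compound 3 by pentyl in place of hydrogen on a selenium, which is the same change as from compound 2 to compound 1. Because that earlier change gave a 1.2-fold higher number from compound 2 to compound 1 (0.08 log units; within the scatter), the step from compound 3 to compound 4 is expected to be about a 1.1-fold higher number from compound 3 to compound 4 (0.03 log units; within the scatter) in this assay. Compound 4 is therefore estimated at 48000 nM, expected to fall between 20000 nM and 110000 nM.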

Compound 4, concentration for 50% growth inhibition: 8780 nM
The estimate for compound 4 lay 5.5-fold (0.74 log units) above the measured number; the whole stated range lies above it.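

In this assay, pentyl in place of hydrogen on the selenium gave a 5.0-fold lower number from compound 3 to compound 4 (0.70 log units; beyond the scatter), whereas the same change on the core of compound 1 stayed within the scatter. The effect of this change therefore did not carry from one core to the other: the same change on two cores in this assay, a 1.2-fold higher number (0.08 log units; within the scatter) from compound 2 to compound 1 and a 5.0-fold lower number (0.70 log units; beyond the scatter) from compound 3 to compound 4, 6.1-fold (0.79 log units) apart, beyond the scatter of two such steps This shows that the outcome differs between these two pairs, but two pairs cannot show which feature of the cores matters or predict the result on a third core.

As far as these compounds go, it remains open whether the lower number on the core of compound 3 is specific to pentyl. A shorter chain such as methyl or a longer chain such as octyl on the selenium of that core could test this.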